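This account rests on a few compounds, and the source may have more. Where it says the series, first, only, none or still open, it means among the compounds named here.

Measured compounds:
Compound 1, `Clc1ccccc1-c1ccc2[nH]ncc2c1`, in an assay on CHO-TREX cells for antagonist activity at transient receptor potential cation channel subfamily A member 1 (Homo sapiens), read by FLIPR and calcium flux, with a stated time of 10 min (a higher number here means a weaker inhibitor, a lower number a stronger inhibitor), compound 1 gives 1230 nM.
Compound 2, `c1ccc(-c2ccc3[nH]ncc3c2)cc1`, gives only a limit of the assay in this assay; compound 2 is reported as > 30000 nM.
Compound 3, `Cc1ccccc1-c1ccc2[nH]ncc2c1`, in this assay compound 3 gives 7810 nM.

Among the two numbers that are not limits, compound 3 stands highest in this assay, with compound 1 nearest: a 6.3-fold higher number from compound 1 to compound 3 (0.80 log units; beyond the scatter). Compound 2 sits at the limit of > 30000 nM in this assay, at which 1 of the 3 values shown sits.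

Compound 4, `CC(C)c1ccccc1-c1ccc2[nH]ncc2c1`, has not been measured. It differs from compound 3 in one place: isopropyl in place of methyl on an aromatic carbon. Among the compounds with values here, the steps that bear on this change are those that alter the same aromatic carbon. The step of an at least 3.8-fold lower number from compound 2 to compound 3 (0.58 log units; beyond the scatter) shows that placing a methyl on this carbon lowered the number. The step of a 6.3-fold higher number from compound 1 to compound 3 (0.80 log units; beyond the scatter) shows that a chloro on this carbon gives a lower number than a methyl. A larger alkyl group is expected to move the number in the same direction as the methyl did, so the estimated step is a 2.2-fold lower number from compound 3 to compound 4 (0.35 log units; beyond the scatter). Compound 4 is therefore estimated at 3500 nM in this assay, within a range of 1000 nM to 15000 nM.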

Compound 4, half-maximal inhibitory concentration: 514 nM
The estimate for compound 4 lay 6.8-fold (0.83 log units) above the measured number; measured number below the stated range.
By their numbers in this assay, from the lowest: compound 4; then compound 1; then compound 3. At a limit, above all of these: compound 2.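

In this assay, the change at this aromatic carbon did not end with methyl: isopropyl in place of methyl gives a 15-fold lower number from compound 3 to compound 4 (1.18 log units; beyond the scatter), and isopropyl in place of chloro gives a 2.4-fold lower number from compound 1 to compound 4 (0.38 log units; beyond the scatter), so chloro no longer holds the lowest number at this carbon. Among the alkyl substituents and hydrogen, the number now falls from hydrogen through methyl to isopropyl, with chloro lying between methyl and isopropyl. The whole span from hydrogen (an at least 58-fold lower number from compound 2 to compound 4 (1.76 log units; beyond the scatter)) is open-ended, as compound 2 gives a limit and not a number: the limit of > 30000 nM in this assay, at which 1 of the 4 values shown sits.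

The compounds shown leave open whether the fall continues with a tert-butyl or cyclopropyl group, and where ethyl would fall. They also leave open how a methoxy group or an amine on this carbon would compare with chloro and isopropyl.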